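This account rests on a few compounds, and the source may have more. Where it says the series, first, only, none or still open, it means among the compounds named here.

Compound 1 `O=c1c2ccccc2[se]n1-c1nc(SCc2ccccc2)n[nH]1` carries a benzyl on the sulfur of the shared core. In a functional assay on A549 cells (Homo sapiens) for antiproliferative activity, read by CCK-8 assay, with a stated time of 48 h (on this read-out lower numbers stand for stronger inhibition and higher numbers for weaker inhibition), compound 1 gives > 50000 nM, which is a limit of the assay rather than a number, so compound 1 stands at the limit of > 50000 nM in this assay, at which 1 of the 3 values shown sits. Compound 2 `Cc1cccc(CSc2n[nH]c(-n3[se]c4ccccc4c3=O)n2)c1` gives 12400 nM in this assay, and compound 3 `O=c1c2ccccc2[se]n1-c1nc(SCc2ccc(Cl)cc2)n[nH]1` gives 42100 nM. Compound 4 `CC(C)Sc1n[nH]c(-n2[se]c3ccccc3c2=O)n1` differs from compound 1 by isopropyl in place of benzyl on a sulfur. The measured steps alter only groups on the benzyl ring: an at least 4.0-fold lower number from compound 1 to compound 2 (0.60 log units; beyond the scatter) and an at least 1.1-fold lower number from compound 1 to compound 3 (0.07 log units; that floor lies within the scatter), while a 3.4-fold higher number from compound 2 to compound 3 (0.53 log units; beyond the scatter). Within the data shown here, no measured step removes the benzyl itself, so these steps bear on the change only loosely. Since compound 1 sits at the limit of > 50000 nM in this assay, at which 1 of the 3 values shown sits, compound 4 is expected to stay weak, with a step that the limit leaves unreadable from compound 1 to compound 4 estimated. The estimate for compound 4 is 60000 nM, within a range from 15000 nM to 250000 nM.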

Compound 4, half-maximal inhibitory concentration: 36600 nM
Compound 4: the middle estimate sits 1.6-fold (0.21 log units) above what was measured; low and high end bracket the measured number.
By their numbers in this assay, from the lowest: compound 2; then compounds 4 and 3 (each within the scatter of the next). At a limit, above all of these: compound 1.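

Isopropyl, which has no ring, gives a measured number on this sulfur, so this series does not need the benzyl ring to give one. Isopropyl gives a 1.2-fold lower number from compound 3 to compound 4 (0.06 log units; within the scatter) and a 3.0-fold higher number from compound 2 to compound 4 (0.47 log units; beyond the scatter) and so matches the 4-chlorobenzyl of compound 3 but not the 3-methylbenzyl of compound 2. The remaining step, an at least 1.3-fold lower number from compound 1 to compound 4 (0.13 log units; that floor lies within the scatter), is only a floor, since the value of compound 1 is a limit: the limit of > 50000 nM in this assay, at which 1 of the 4 values shown sits.

From the compounds shown here alone, whether a longer straight chain, or a chain ending in an amine or a carboxylic acid, would fare better on this sulfur remains open. So does whether any group here can beat the 3-methylbenzyl of compound 2.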